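The source may report more compounds than this note shows. Statements on the series, on what has been measured and on what is new or still open speak of the compounds shown alone.

Measured in an ADME assay on MT4 cells (Homo sapiens) for cytotoxicity, with a stated time of 5 days; on this read-out higher numbers stand for lower toxicity in this test and lower numbers for higher toxicity in this test:
- compound 1 `CC(C)N(C(=O)C1CCCCC1)c1cc(C#CC(C)(C)C)sc1C(=O)O`: > 20000 nM, a limit
- compound 2 `CC(C)N(C(=O)C1CCC(F)(F)CC1)c1cc(C#CC(C)(C)C)sc1C(=O)O`: > 20000 nM, a limit

Compound 2 has no numerical value in this assay. Its result of > 20000 nM is a limit of the assay. Both measured compounds share this position: the limit of > 20000 nM in this assay, at which 2 of the 2 values shown sit.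

The next compound, compound 3 `CC(C)N(c1cc(C#CC(C)(C)C)sc1C(=O)O)C(=O)[C@H]1CC[C@H](CF)CC1`, carries 4-(fluoromethyl)cyclohexyl in place of 4,4-difluorocyclohexyl on a carbonyl carbon. Its ring remains a six-membered non-aromatic ring of carbon only, and it has 2 defined stereocentres.

Among the compounds with values here, the one measured step that bears on this change is a step that the two limits leave unreadable from compound 1 to compound 2. It was made at the same carbonyl carbon, but it gives no size to carry forward. With no readable step in the series, no step beyond the scatter is expected in this assay, and no direction can be assigned. The expected result is a step that the limit leaves unreadable from compound 2 to compound 3. A further limit is the most likely report. For compound 3 the estimated half-maximal cytotoxic concentration is 22000 nM, with an expected range of 12000 nM to 40000 nM.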

Compound 3, half-maximal cytotoxic concentration: > 20000 nM
Compound 3 gave a limit, no number; the forecaster's own chance of this, stated with the estimate: 85%; the middle value is on the limit's open side.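

In this assay compound 3 gives > 20000 nM, a limit and not a number. No new step can be read from compound 1 or compound 2 to compound 3. The compounds shown leave open whether changes at this carbonyl carbon alter the read-out at all, with all three sharing one position: the limit of > 20000 nM in this assay, at which 3 of the 3 values shown sit.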